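This account rests on a few compounds, and the source may have more. Where it says the series, first, only, none or still open, it means among the compounds named here.

Measured so far:
- compound 1, `COc1ccc(-c2nc(CNC(=O)c3cccnc3)sc2-c2ccc(OC)cc2)cc1`: 25 nM
- compound 2, `COc1ccc(-c2nc(/C=C/C(=O)N3CCN(C)CC3)sc2-c2ccc(OC)cc2)cc1`: > 1000 nM

Going by the values given here, compound 1 is the only compound with a number in a functional assay with Oryctolagus cuniculus as the target; a higher number here means a weaker inhibitor, a lower number a stronger inhibitor; in this assay compound 1 gives 25 nM. For compound 2 this assay reports only a limit, > 1000 nM. The other value shown is therefore (the limit of > 1000 nM in this assay, at which 1 of the 2 values shown sits), so compound 1 stands as the single fixed point against which anything further is judged.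

Compound 3, `COc1ccc(-c2nc(CCC(=O)O)sc2-c2ccc(OC)cc2)cc1`, has not yet been measured in this assay. Its difference from compound 1 is carboxymethyl in place of ((pyridin-3-yl)carbonyl)amino on a saturated chain carbon bound to an aromatic carbon: the pyridinyl amide is gone and a carboxylic acid on a short chain takes its place. Among the compounds with values here, with no measured step along this line, the step from compound 1 to compound 3 is expected to be a weakening well beyond the usual scatter, a 32-fold higher number from compound 1 to compound 3 (1.51 log units; beyond the scatter). Compound 3 is expected to give about 800 nM, within 150 nM to 5000 nM.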

Compound 3, half-maximal inhibitory concentration: < 100 nM
Compound 3: only a limit was reported; the forecaster's own chance of this, stated with the estimate: 40%; middle value at least 8.0-fold (0.90 log units) from the limit.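

In this assay compound 3 gives < 100 nM, which is a limit and not a number. Going by these compounds alone, no step between compound 1 and compound 3 can be read from it. Still open, going by these compounds, is whether swapping the pyridinyl amide for the carboxylic acid chain strengthens or weakens inhibition.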